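The source may hold more compounds than are shown below. What is called first, only, known or untested is meant among the compounds shown, and "the series" means these compounds.

Maximal response in a functional assay on HeLa cells for agonist activity at 5-hydroxytryptamine receptor 6 (Homo sapiens), read by immunoassay (a lower number here means a smaller maximal response, a higher number a larger maximal response), for the measured members of the series:

compound 1 `CN(C)CCn1cc(S(=O)(=O)c2ccccc2)c2cccnc21`: 94%
compound 2 `CN(C)CCn1cc(S(=O)(=O)c2c(Cl)cccc2Cl)c2cccnc21`: 66%

Among the measured compounds shown here, compound 2 holds the lowest of the two numbers in this assay; its nearest neighbour is compound 1, and the only measured step, a number 28 percentage points lower from compound 1 to compound 2 (beyond the scatter), is the difference between them. Compound 3 `CN(C)CCn1cc(S(=O)(=O)c2ccc(Cl)s2)c2cccnc21` is unmeasured and differs from compound 2 in one place: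

5-chlorothiophen-2-yl in place of 2,6-dichlorophenyl on a sulfonyl sulfur

For the measured compounds named here, the one step that bears on this change is a number 28 percentage points lower from compound 1 to compound 2 (beyond the scatter), a modest drop, but it concerns phenyl giving way to 2,6-dichlorophenyl on the sulfonyl sulfur, not a switch to a five-membered ring. Going by the values given here, no measured pair covers 5-chlorothiophen-2-yl in place of 2,6-dichlorophenyl on a sulfonyl sulfur, so the direction is uncertain; given that compound 1 gives 94% with the plain ring, a modest recovery toward that level is expected for compound 3, a number 12 percentage points higher from compound 2 to compound 3 (beyond the scatter). Compound 3 is estimated at 78% in this assay, within a range of 58% to 95%.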

Compound 3, largest response reached (Emax), in percent of the reference or control that the assay uses: 93%
The estimate for compound 3 lay 15 percentage points below the measured number; the range from low to high includes it.
By their numbers in this assay, from the lowest: compound 2; then compounds 3 and 1 (each within the scatter of the next).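

In this assay, 5-chlorothiophen-2-yl in place of 2,6-dichlorophenyl on the sulfonyl sulfur gives a number 27 percentage points higher from compound 2 to compound 3 (beyond the scatter), so a chlorine-bearing aromatic group at this position does not by itself bring the lower response seen for compound 2. Set against phenyl, the same group gives a number 1 percentage points lower from compound 1 to compound 3 (within the scatter), which leaves compound 1 and compound 3 indistinguishable in this read-out and makes 2,6-dichlorophenyl the only one of the three groups that stands apart. Nothing available here accounts for that difference.

Open, as far as these compounds go, is whether the ring or the number of chlorines matters more: a thiophen-2-yl without chlorine and a phenyl carrying a single chlorine would separate the two. Also open, from the compounds shown here alone, is whether the pattern holds with a pyrrolidine in place of the dimethylamino group.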